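Compound 4: A Dichlorophenyl Swap in HepG2 Cytotoxicity

The source may report more compounds than this note shows. Statements on the series, on what has been measured and on what is new or still open speak of the compounds shown alone.

In a functional assay on HepG2 cells (Homo sapiens) for cytotoxicity, read by MTT assay, with a stated time of 72 h (a higher number here means a weaker inhibitor, a lower number a stronger inhibitor), compound 1 `CN1CCN(c2ccc(Nc3ncc4nc(Nc5ccccc5)n(-c5ccccc5)c4n3)cc2)CC1` returns only a limit (> 5000 nM). Compound 2 `c1ccc(Nc2ncc3nc(Nc4ccccc4)n(C4CCCC4)c3n2)cc1` also returns only a limit (> 5000 nM). For the measured compounds named here, compound 3 `C#Cc1cccc(Nc2nc3cnc(Nc4ccc(N5CCN(C)CC5)cc4)nc3n2C2CCCC2)c1` gives 4900 nM as the only actual number in the set, so it offers the single firm reference point.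

Compound 4 `CN1CCN(c2ccc(Nc3ncc4nc(Nc5cc(Cl)ccc5Cl)n(C5CCCC5)c4n3)cc2)CC1` remains unmeasured. It has 2,5-dichlorophenyl in place of 3-ethynylphenyl on a nitrogen on an aromatic ring. Going by the values given here, no measured pair in the set isolates this change, so nothing shows directly how it acts. In this assay a step no larger than the usual scatter is therefore expected, with no firm direction. This expectation rests on compound 3 at 4900 nM. It also rests on (the limit of > 5000 nM in this assay, at which 2 of the 3 values shown sit). The expected change is small (a 1.1-fold lower number from compound 3 to compound 4 (0.04 log units; within the scatter)). A reading that is only a limit would be no surprise. Compound 4 is estimated at 4500 nM, with an expected range from 1800 nM to 10000 nM.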

Compound 4, half-maximal inhibitory concentration: > 5000 nM
Compound 4: a limit, no number; the forecaster's own chance of this, stated with the estimate: 50%; middle value at least 1.1-fold (0.04 log units) from the limit.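

For the compounds shown here, the swap of 3-ethynylphenyl for 2,5-dichlorophenyl on a nitrogen on an aromatic ring provides the first step that can be read in this assay: an at least 1.0-fold higher number from compound 3 to compound 4 (0.00 log units; that floor lies within the scatter). Compound 4 gives > 5000 nM, which is a limit and not a number, so the step sets only a floor and gives no size. The change thus yields no second firm reading to set beside compound 3, and the new result joins the most common reading in the set: the limit of > 5000 nM in this assay, at which 3 of the 4 values shown sit.

From the compounds shown here alone, how far compound 4 truly lies from compound 3 stays open, and the direction of any real difference cannot be told. Nor do the compounds shown say how a carboxylic acid, an amine or a longer chain in place of the 2,5-dichlorophenyl group would read on that nitrogen.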